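The source may hold more compounds than are shown below. What is called first, only, known or untested is meant among the compounds shown, and "the series" means these compounds.

Compounds measured so far in a functional assay on SV5A8 cells (Homo sapiens) for cytotoxicity; a higher number here means a weaker inhibitor, a lower number a stronger inhibitor:

- compound 1 `Cc1ccc2c(NCc3ccc(NC(=O)C4CCN(Cc5ccccc5)CC4)cc3)nc(N3CCCCCC3)nc2c1`: compound 1 gives > 6880 nM, a limit of the assay.
- compound 2 `Cc1ccc2c(NCc3ccc(NC(=O)C4CCN(Cc5cc(Cl)ccn5)CC4)cc3)nc(N(C)C)nc2c1`: compound 2 gives > 5400 nM, a limit of the assay.
- compound 3 `Cc1ccc2c(NCc3ccc(NC(=O)C4CCN(Cc5ccccc5)CC4)cc3)nc(N3CCN[C@@H](C)C3)nc2c1`: compound 3 gives > 8860 nM, a limit of the assay.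

Going by the values given here, compound 1 stands on a limit only in this assay, and the two other values shown are limits as well; no compound in this set has a numerical read-out. Among the compounds with values here, the one single-point comparison, a step that the two limits leave unreadable from compound 1 to compound 3, is therefore unreadable in size and direction, as both ends sit on a limit (the limit of > 6880 nM in this assay, at which 1 of the 3 values shown sits, and (the limit of > 8860 nM in this assay, at which 1 of the 3 values shown sits)). The remaining value, (the limit of > 5400 nM in this assay, at which 1 of the 3 values shown sits), belongs to compound 2 and adds no readable step.

The unmeasured compound 4 `Cc1ccc2c(NCc3ccc(NC(=O)C4CCN(Cc5ccccc5)CC4)cc3)nc(N3CCC(N4CCCC4)CC3)nc2c1` differs from compound 1 in one place: 4-(pyrrolidin-1-yl)piperidin-1-yl in place of azepan-1-yl on an aromatic carbon. Within the data shown here, no measured step bears on this change in a readable way, so nothing points toward a step beyond the scatter in either direction; the weight of the set rests on three limits, and compound 4 is expected to sit at a limit too.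

Compound 4 is therefore estimated at 10000 nM in this assay, with a range of 4000 nM to 30000 nM. The expected step that the limit leaves unreadable from compound 1 to compound 4 is an estimate only, as compound 1 itself sits on a limit.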

Compound 4, half-maximal inhibitory concentration: > 8090 nM
Compound 4 was reported as a limit; the forecaster's own chance of this, stated with the estimate: 85%; the middle value lies beyond the limit too.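

In this assay compound 4 gives > 8090 nM, a limit of the assay. Compound 1 and compound 3 also stand on limits, so neither step to compound 4 can be read in size or direction. The compounds shown leave open whether exchanging the group on this aromatic carbon changes the read-out in this assay at all.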